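A few compounds are considered here, and "the series" means these few. Any claim that something is new, unique, unknown or untested is made for them only; others in the source may bear on it.

Working notes on the series, read in a functional assay on A549 cells (Homo sapiens) for cytotoxicity, read by MTT assay, with a stated time of 48 h; a lower number here means a stronger inhibitor, a higher number a weaker inhibitor:

compound 1, `C=CC(=C)CC[C@@H]1[C@@]2(C)CCC[C@](C)(COC(=O)/C=C/c3ccc(O)cc3)[C@@H]2CC[C@@]1(C)O` — 20400 nM
compound 2, `C=C1CC[C@@H]2[C@](C)(CCC[C@]2(C)C(=O)O)[C@H]1CC/C(C)=C/CO` — > 40000 nM, a limit of the assay
compound 3, `C=CC(=C)[C@@H](O)C[C@H]1C(=C)CC[C@@H]2[C@]1(C)CCC[C@]2(C)C(=O)O` — > 40000 nM, a limit of the assay

Compound 3 stands at the top end of what this assay reports: its value is a limit, not a number. Compound 2 sits at the same limit. Among the measured compounds shown here, the only single-point step in the set, a step that the two limits leave unreadable from compound 2 to compound 3, is therefore unreadable; it tells nothing about how much the exchange of one chain for another moved the result. The wider picture is the limit of > 40000 nM in this assay, at which 2 of the 3 values shown sit, so most of the series is simply too weak to be resolved here.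

The step now followed is from compound 3 to compound 4, `C=C[C@@]1(C)O[C@H]1C[C@H]1C(=C)CC[C@@H]2[C@]1(C)CCC[C@]2(C)C(=O)O`. The change is a group of 6 heavy atoms (5 carbon, 1 oxygen; one three-membered non-aromatic ring with 1 hetero atom) in place of a group of 6 heavy atoms (5 carbon, 1 oxygen; no ring), on a saturated chain carbon bound to a saturated ring carbon. For the measured compounds named here, no measured step in the set bears on an exchange of this kind, and the one step that exists is unreadable. Without a measured reference, no direction can be read off; what is known is that compound 3 sits at the limit and that the change keeps the core and the acid untouched.

Compound 4 is accordingly expected to stay in the same weak region, with the step that the limit leaves unreadable from compound 3 to compound 4 estimated as no more than the scatter. Compound 4 is estimated at 45000 nM, within 15000 nM to 150000 nM, with a real chance that this assay again returns only a limit.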

Compound 4, half-maximal inhibitory concentration: > 40000 nM
Compound 4 ended at the assay's limit; the forecaster's own chance of this, stated with the estimate: 60%; the middle value lies beyond the limit too.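

In this assay compound 4 gives > 40000 nM, a limit of the assay and not a number. The steps joining compound 2, compound 3 and compound 4 all run between limits and cannot be read. Left open by the compounds shown is whether any of these chain exchanges on the shared core moves the result at all, because the read-out stops at one point: the limit of > 40000 nM in this assay, at which 3 of the 4 values shown sit.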